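Side chain ether variants on the shared core

This account rests on a few compounds, and the source may have more. Where it says the series, first, only, none or still open, it means among the compounds named here.

Of the compounds shown here, three on the shared core have been read in a functional assay on DU-145 cells (Homo sapiens) for cytotoxicity, read by MTT assay (on this read-out higher numbers stand for weaker inhibition and lower numbers for stronger inhibition), so far. Compound 1 `COC(C)CO[C@H](CC=C(C)C)C1=CC(=O)c2c(O)ccc(O)c2C1=O` gives 16600 nM. Compound 2 `CC(C)=CC[C@@H](OC(=O)C1CCOC1)C1=CC(=O)c2c(O)ccc(O)c2C1=O` gives 47500 nM, and the step of a 2.9-fold higher number from compound 1 to compound 2 (0.46 log units; beyond the scatter) is the only one in the set that lies beyond the scatter. Compound 3 `CC(=O)OC(C)CO[C@H](CC=C(C)C)C1=CC(=O)c2c(O)ccc(O)c2C1=O` gives 16600 nM, so that no change at the digits printed from compound 1 to compound 3 (within the scatter) and a 2.9-fold lower number from compound 2 to compound 3 (0.46 log units; beyond the scatter). Compound 3 therefore stands level with compound 1 at the digits shown, the two together being the lowest numbers of the three, with compound 2 the furthest away.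

The next compound, compound 4 `CCC(O)CO[C@H](CC=C(C)C)C1=CC(=O)c2c(O)ccc(O)c2C1=O`, is not yet measured. It differs from compound 3 as follows: 1-hydroxypropyl in place of 1-acetoxyethyl on a saturated chain carbon bound to an oxygen on a saturated carbon.

The step that bears most directly on this change is no change at the digits printed from compound 1 to compound 3 (within the scatter), where swapping acetyl for methyl on the same oxygen left the number unchanged. The steps through compound 2 concern the ester replacement rather than the present change and are not taken as a guide. On that basis the step of a 1.0-fold lower number from compound 3 to compound 4 (0.02 log units; within the scatter) is expected to stay within the scatter. The value of compound 4 in this assay is estimated at 16000 nM, with a range from 8000 nM to 35000 nM.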

Compound 4, half-maximal inhibitory concentration: 16400 nM
Compound 4: middle estimate off by 1.0-fold (0.01 log units), on the low side, within the range that was stated.
By their numbers in this assay, from the lowest: compounds 4, 1 and 3 (each within the scatter of the next); then compound 2.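

In this assay, the step to 1-hydroxypropyl in place of 1-acetoxyethyl, a 1.0-fold lower number from compound 3 to compound 4 (0.01 log units; within the scatter), shows that this saturated chain carbon bound to an oxygen on a saturated carbon can take a group with 1 hydrogen-bond donor in place of one with none, and 4 heavy atoms in place of 6, with no shift outside the scatter. The step from 1-methoxyethyl, a 1.0-fold lower number from compound 1 to compound 4 (0.01 log units; within the scatter), gives the same reading, so compound 1, compound 3 and compound 4 sit level within the scatter despite these different end groups. Compound 2 remains the one apart, at a 2.9-fold lower number from compound 2 to compound 4 (0.46 log units; beyond the scatter), with 2-hydroxybutyl in place of (oxolan-3-yl)carbonyl on the oxygen, and no data accompany these numbers that would explain either the level reading or this gap.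

Still open, as far as these compounds go, is whether the level reading would hold with a primary amine or a carboxylic acid at this place, or with a chain longer than 2-hydroxybutyl. Also open is whether the reading for compound 4 would carry over to cell lines other than the one shown here.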